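Pyrazole chalcones: carbonyl aryl swap on the pyridin-4-yl core

The source may hold more compounds than are shown below. What is called first, only, known or untested is meant among the compounds shown, and "the series" means these compounds.

Compound 1 `O=C(/C=C/c1cn(-c2ccccc2)nc1-c1cccnc1)c1cc[nH]c1` gives 6900 nM in a functional assay on MCF7 cells (Homo sapiens) for inhibition, read by sulforhodamine B assay, with a stated time of 72 h; a lower number here means a stronger inhibitor, a higher number a weaker inhibitor. Compound 2 `O=C(/C=C/c1cn(-c2ccccc2)nc1-c1cccnc1)c1ccccc1` gives 4100 nM; the change phenyl in place of 1H-pyrrol-3-yl on a carbonyl carbon made a step of a 1.7-fold lower number from compound 1 to compound 2 (0.23 log units; within the scatter). Compound 3 `O=C(/C=C/c1cn(-c2ccccc2)nc1-c1ccncc1)c1cc[nH]c1` gives 13600 nM; its core differs from that of compound 1 by pyridin-4-yl in place of pyridin-3-yl on an aromatic carbon, with a step of a 2.0-fold higher number from compound 1 to compound 3 (0.29 log units; within the scatter). Among the compounds with values here, no step between compound 2 and compound 3 is broken down here; their two values lie beyond the scatter of each other.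

Compound 4 `O=C(/C=C/c1cn(-c2ccccc2)nc1-c1ccncc1)c1ccccc1` is not yet measured. It differs from compound 3 by phenyl in place of 1H-pyrrol-3-yl on a carbonyl carbon, the same change as from compound 1 to compound 2, at a place described in the same words. The step of a 1.7-fold lower number from compound 3 to compound 4 (0.23 log units; within the scatter) is expected to resemble the earlier one, because that step was a 1.7-fold lower number from compound 1 to compound 2 (0.23 log units; within the scatter). Compound 4 is therefore estimated at 8000 nM, between 3500 nM and 18000 nM.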

Compound 4, half-maximal inhibitory concentration: 3400 nM
For compound 4 the middle estimate is 2.4-fold (0.37 log units) above the measured one; measured number below the stated range.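

Phenyl in place of 1H-pyrrol-3-yl on the carbonyl carbon gives a 4.0-fold lower number from compound 3 to compound 4 (0.60 log units; beyond the scatter) in this assay, and this step does not differ from its counterpart on the other core: the same change on two cores in this assay, a 1.7-fold lower number (0.23 log units; within the scatter) from compound 1 to compound 2 and a 4.0-fold lower number (0.60 log units; beyond the scatter) from compound 3 to compound 4, 2.4-fold (0.38 log units) apart, within the scatter of two such steps

Pyridin-4-yl in place of pyridin-3-yl gives a 1.2-fold lower number from compound 2 to compound 4 (0.08 log units; within the scatter), and this step also agrees with its counterpart: the same change on two cores in this assay, a 2.0-fold higher number (0.29 log units; within the scatter) from compound 1 to compound 3 and a 1.2-fold lower number (0.08 log units; within the scatter) from compound 2 to compound 4, 2.4-fold (0.38 log units) apart, within the scatter of two such steps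

Both changes therefore carry from one core to the other within the scatter, but two cores fix no exact size for either change and show nothing about a third core.

Open, as far as these compounds go, is whether the carbonyl step follows the hydrogen-bond donor that leaves with 1H-pyrrol-3-yl. Also open, from the compounds shown here alone, is how a benzoyl carrying an amine or a carboxylic acid would behave on either core.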